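This account rests on a few compounds, and the source may have more. Where it says the series, first, only, none or still open, it means among the compounds named here.

Three analogues of the shared core of compound 1 `CC(/C=N/Nc1ccc([N+](=O)[O-])cc1)=N\NC(=O)c1ccccc1F` have been measured in a functional assay on cells (Splenocyte, Mus musculus, strain BALB/c) for inhibition, read by scintillation counting and thymidine incorporation, with a stated time of 72 h; a higher number here means a weaker inhibitor, a lower number a stronger inhibitor. Compound 1 reaches only the limit > 12000 nM, which is a bound of the assay and not a number. Compound 2 `CC(/C=N/Nc1ccc([N+](=O)[O-])cc1)=N\NC(=O)c1ccccc1C` gives 6000 nM, and compound 3 `CC(/C=N/Nc1ccc([N+](=O)[O-])cc1)=N\NC(=O)c1ccccc1N` gives 4900 nM. The change an at least 2.0-fold lower number from compound 1 to compound 2 (0.30 log units; that floor lies within the scatter) and the change an at least 2.4-fold lower number from compound 1 to compound 3 (0.38 log units; beyond the scatter) both start from a limit, and the change a 1.2-fold lower number from compound 2 to compound 3 (0.09 log units; within the scatter) is small. Compound 3 therefore carries the lowest of the two plain numbers, with compound 2 close by.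

Compound 4 `CC(/C=N/Nc1ccc([N+](=O)[O-])cc1)=N\NC(=O)c1cccc(C)c1` takes the step (3-methylphenyl in place of 2-aminophenyl on a carbonyl carbon). Among the compounds with values here, no measured step swaps both the group and its position at once; the nearest reference is the exchange of amino for methyl on an aromatic carbon, a 1.2-fold lower number from compound 2 to compound 3 (0.09 log units; within the scatter), which stayed within scatter. On that basis the step of a 1.2-fold higher number from compound 3 to compound 4 (0.09 log units; within the scatter) is expected to be small, in either direction, or none beyond the scatter. Compound 4 is expected to give about 6000 nM in this assay, within a range of 3000 nM to 13000 nM.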

Compound 4, half-maximal inhibitory concentration: > 12000 nM
Compound 4 was reported as a limit (the forecaster's own chance of this, stated with the estimate: 25%); middle value at least 2.0-fold (0.30 log units) away from the limit.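

In this assay compound 4 gives > 12000 nM, which is a limit of the assay and not a number. Taking 3-methylphenyl in place of 2-aminophenyl on a carbonyl carbon gives an at least 2.4-fold higher number from compound 3 to compound 4 (0.38 log units; beyond the scatter), the first readable loss at this place from a plain number, whereas the same group in place of 2-methylphenyl gives an at least 2.0-fold higher number from compound 2 to compound 4 (0.30 log units; that floor lies within the scatter), so moving the methyl alone is not shown to matter beyond the scatter. The step between compound 1 and compound 4 cannot be read, as both readings are limits: the limit of > 12000 nM in this assay, at which 2 of the 4 values shown sit.

From the compounds shown here alone, the true size of both readable steps stays open, since each rests on a floor. Also open, going by these compounds, is how 3-aminophenyl or 2-methoxyphenyl on the same carbonyl carbon would read in this assay.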